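This account rests on a few compounds, and the source may have more. Where it says the series, first, only, none or still open, it means among the compounds named here.

Compound 1 `COc1ccc(C(O)C2OC(=O)c3c(OC)cc(OC)cc32)cc1`: in an ADME assay on RAW264.7 cells (Mus musculus) for cytotoxicity, read by MTT assay, with a stated time of 24 h, in the presence of a further agent that is not named here (a lower number here means a stronger inhibitor, a higher number a weaker inhibitor), compound 1 gives > 40000 nM, which is a limit of the assay rather than a number.
Compound 2 `C=CCCOc1ccc(C(O)C2OC(=O)c3c(OC)cc(OC)cc32)cc1`: in this assay compound 2 gives > 40000 nM, again a limit and not a number.

Within the data shown here, compound 2 therefore stands at the upper edge of what this assay can report, and so does the only compound it can be set against: the limit of > 40000 nM in this assay, at which 2 of the 2 values shown sit. Among the measured compounds shown here, the one measured step, a step that the two limits leave unreadable from compound 1 to compound 2, cannot be given a size because both of its ends sit at that limit (the limit of > 40000 nM in this assay, at which 2 of the 2 values shown sit). Compound 3 `COc1cc(OC)c2c(c1)C(C(O)c1ccc(OCC3CCCCC3)cc1)OC2=O` differs from compound 2 by cyclohexyl in place of allyl on a saturated chain carbon bound to an oxygen on an aromatic ring. The step that the two limits leave unreadable from compound 1 to compound 2 changed the same position and offers no readable size to build on. The expected step that the limit leaves unreadable from compound 2 to compound 3 is thus none beyond the scatter, with a strong chance that only a limit is reported again. Compound 3 is estimated at 50000 nM, with a range from 20000 nM to 150000 nM.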

Compound 3, half-maximal inhibitory concentration: > 40000 nM
Compound 3 ended at the assay's limit; the forecaster's own chance of this, stated with the estimate: 80%; the middle value is on the limit's open side.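

Compound 3 gives only a limit, as do compound 1 and compound 2, so the steps from compound 1 and compound 2 to compound 3 cannot be read: the limit of > 40000 nM in this assay, at which 3 of the 3 values shown sit. The compounds shown leave open whether any group at this place would give a true number in this assay.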